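A few compounds are considered here, and "the series" means these few. Any claim that something is new, unique, unknown or untested is made for them only; others in the source may bear on it.

Two esters of related phenolic cores open the comparison. Compound 1, `CC1=CC[C@H](C(C)C)c2cc(C)c(OC(=O)c3ccc(C)cc3)cc21`, carries a methyl-substituted benzoate, and in a functional assay on PC-3 cells (Homo sapiens) for antiproliferative activity, read by sulforhodamine B assay, with a stated time of 48 h, tested at 50 uM (on this read-out lower numbers stand for less inhibition and higher numbers for more inhibition at the one concentration tested (going by the name of the read-out)), compound 1 gives 49.6%. Compound 2, `Cc1cc2c(C(C)C)ccc(C)c2cc1OC(=O)c1cccc(C(F)(F)F)c1`, carries a trifluoromethyl-substituted benzoate on an aromatic core, and in this assay compound 2 gives 26.7%. Among the measured compounds shown here, on these two numbers compound 2 stands lowest, with compound 1 its only neighbour, a gap that lies beyond the usual scatter of such measurements. The two compounds differ in more than one place, so what their values show is simply the gap between them and nothing about any single change.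

Compound 3, `COc1cccc(C(=O)Oc2cc3c(C)ccc(C(C)C)c3cc2C)c1`, keeps the core and the ester of compound 2 and differs from it in one group: methoxy in place of trifluoromethyl on an aromatic carbon. For the measured compounds named here, no measured pair illustrates this exchange, so the direction of the step is open. Compound 3 is expected to lie a modest step above compound 2, the estimated change being a number 8.3 percentage points higher from compound 2 to compound 3 (within the scatter), with the expectation resting only on the standing of compound 2 at 26.7%. For compound 3 the estimated value in this assay is 35%, with a range from 15% to 55%.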

Compound 3, a percentage reported as inhibition, at one concentration (the size of the read-out at that concentration, not a potency): 12.5%
Beside the measured number, compound 3's estimate is 22.5 percentage points above it, outside the stated range (below it).
By their numbers in this assay, from the lowest: compound 3; then compound 2; then compound 1.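

Among the compounds shown here, this exchange gives the first step that can be read in one place, and it settles the direction left open before: on an aromatic carbon of the six-membered aromatic ring, meta to a large group, methoxy in place of trifluoromethyl gives a number 14.2 percentage points lower from compound 2 to compound 3 (beyond the scatter) in this assay. The change therefore matters at this position, since a swap of one group with the rest of the structure kept lowers the inhibition to a degree beyond the usual scatter, leaving compound 3 at 12.5%. The step itself replaces a group of four heavy atoms and no hydrogen-bond acceptor with one of two heavy atoms and one hydrogen-bond acceptor, but no accompanying measurement links either difference to the lower number, so the reason for the step remains unknown.

For the compounds shown here, with only this single exchange at the position, it stays open whether the step would hold on the core of compound 1, and whether it would have the same direction and size at another place on the ring. As far as these compounds go, how an amine, a carboxylic acid or a longer chain at this position would stand in this assay also stays open.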